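A few compounds are considered here, and "the series" means these few. Any claim that something is new, unique, unknown or untested is made for them only; others in the source may bear on it.

Within the data shown here, only two compounds have been measured so far in a functional assay on FM3A cells (Mus musculus); on this read-out higher numbers stand for weaker inhibition and lower numbers for stronger inhibition. Compound 1 `COc1ccc(C(c2ccc(C(C)C)cc(=O)c2O)c2ccc(C(C)C)cc(=O)c2O)cc1` gives 400 nM, the lower of the two numbers, and compound 2 `CC(C)C1=CC(=O)C(=O)/C(=C2/C=CC(C(C)C)=CC(O)=C2O)C=C1` gives 3700 nM, a gap beyond the usual scatter of repeat measurements. These two differ in more than one place, so their gap does not isolate any single structural change.

Compound 3 `CC(C)c1ccc(Cc2ccc(C(C)C)cc(=O)c2O)c(O)c(=O)c1` has not yet been measured. It departs from compound 1 in one place: hydrogen in place of 4-methoxyphenyl on a saturated chain carbon bound to two aromatic carbons.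

Among the measured compounds shown here, no measured pair in this assay shows this replacement alone, so any expectation here is loose. For the measured compounds named here, the only hint is that compound 2 also has no 4-methoxyphenyl and reads 3700 nM, which points towards a higher number. A moderate weakening is therefore expected, estimated as a 2.8-fold higher number from compound 1 to compound 3 (0.44 log units; beyond the scatter), probably just beyond the scatter. For compound 3 the expected value is 1100 nM, with an estimated range from 300 nM to 4000 nM.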

Compound 3, half-maximal inhibitory concentration: 1000 nM
Estimate against measurement, compound 3: 1.1-fold (0.04 log units) above; the measured number falls inside the stated range.
By their numbers in this assay, from the lowest: compound 1; then compound 3; then compound 2.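

In this assay the series now has its first comparison that differs in one place: hydrogen in place of 4-methoxyphenyl on a saturated chain carbon bound to two aromatic carbons gives a 2.5-fold higher number from compound 1 to compound 3 (0.40 log units; beyond the scatter) in this pair. The step is modest but beyond the scatter, so this position does affect the read-out, and the 4-methoxyphenyl goes with the lower number, although compound 3 without it still reads 1000 nM and the group is therefore not needed for a measurable value. No evidence on any property of these compounds accompanies this single step, so it records the size of the change and offers no explanation for it.

The compounds shown leave open whether the 4-methoxyphenyl is special or whether any group at this place would do the same. A plain phenyl, a 4-hydroxyphenyl or a simple methyl on the same saturated chain carbon would separate the contribution of the methoxy from that of the ring, and would show whether the trend holds beyond this one pair.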